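Adding One Methoxy to Compound 2

The source may report more compounds than this note shows. Statements on the series, on what has been measured and on what is new or still open speak of the compounds shown alone.

Among the compounds with values here, in a functional assay on SW480 cells (Homo sapiens) for antiproliferative activity, read by sulforhodamine B assay, with a stated time of 48 h (a lower number here means a stronger inhibitor, a higher number a weaker inhibitor), compound 1 `COc1cc(C=C(C(=O)/C=C/c2cccc(OC)c2OC)C(=O)/C=C/c2cccc(OC)c2OC)cc(OC)c1O` gives 420 nM and compound 2 `COc1ccc(OC)c(/C=C/C(=O)C(=Cc2ccc(O)c(OC)c2)C(=O)/C=C/c2cc(OC)ccc2OC)c1` gives 410 nM as the only measured values so far. These two numbers lie within the scatter of each other, so compound 2 stands together with compound 1 and the two cannot be told apart on this read-out.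

Compound 3 `COc1ccc(OC)c(/C=C/C(=O)C(=Cc2cc(OC)c(O)c(OC)c2)C(=O)/C=C/c2cc(OC)ccc2OC)c1` is the next to be considered. It differs from compound 2 in one place, with methoxy in place of hydrogen on an aromatic carbon on an aromatic carbon, ortho to a hydroxy group, meta to a large group and meta to a methoxy group. A methoxy thus stands in place of hydrogen, and 4-hydroxy-3-methoxyphenyl becomes 4-hydroxy-3,5-dimethoxyphenyl.

Within the data shown here, no pair of measured compounds shows a step of this kind, so the data give no direction for it. In this assay the expectation is therefore of no change beyond the scatter, and the estimated 1.0-fold lower number from compound 2 to compound 3 (0.01 log units; within the scatter) should be read in that light. Compound 3 is expected at 400 nM (estimated range 150 nM to 1000 nM).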

Compound 3, half-maximal inhibitory concentration: 500 nM
The estimate for compound 3 lay 1.3-fold (0.10 log units) below the measured number, within the range that was stated.
By their numbers in this assay, from the lowest: compounds 2, 1 and 3 (each within the scatter of the next).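

With a 1.2-fold higher number from compound 2 to compound 3 (0.09 log units; within the scatter) in this assay, the series gains its first step between two compounds that differ in one place, something compounds 1 and 2 could not provide. At this position, on an aromatic carbon ortho to a hydroxy group, a methoxy can stand in place of hydrogen with no difference that this read-out can resolve, so compound 2 and compound 3 cannot be told apart and 4-hydroxy-3-methoxyphenyl and 4-hydroxy-3,5-dimethoxyphenyl serve equally well here. Nothing available explains this outcome or links it to any property of the methoxy group.

The compounds shown leave open whether this position would read the same with a longer chain such as ethoxy, with an amine or with a carboxylic acid in place of the hydrogen, since methoxy is the only group seen there so far. They also leave open whether the same methoxy step would read the same on a compound carrying different methoxy groups on the other two aromatic rings, as a single step on a single pair cannot show how far it carries.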